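A cyclohexyl swap in a cytotoxicity test

The source may hold more compounds than are shown below. What is called first, only, known or untested is meant among the compounds shown, and "the series" means these compounds.

In an ADME assay on Huh-7 cells (Homo sapiens) for cytotoxicity, with a stated time of 72 h (on this read-out higher numbers stand for lower toxicity in this test and lower numbers for higher toxicity in this test), compound 1 `CC(C)CCn1nc(-c2cccs2)c(O)c(C2=NS(=O)(=O)c3cc(N(C)S(C)(=O)=O)ccc3N2)c1=O` gives > 33000 nM, which is a limit of the assay. Compound 2 `CC(C)CCn1nc(C2CCCCC2)c(O)c(C2=NS(=O)(=O)c3cc(NS(C)(=O)=O)ccc3N2)c1=O` gives > 1000 nM, also only a limit, so it has no exact place on the scale. Compound 3 `CC(C)CCn1nc(CC2=CCCC2)c(O)c(C2=NS(=O)(=O)c3cc(NS(C)(=O)=O)ccc3N2)c1=O` carries (cyclopent-1-en-1-yl)methyl in place of the cyclohexyl of compound 2 on an aromatic carbon: (cyclopent-1-en-1-yl)methyl in place of cyclohexyl on an aromatic carbon. Going by the values given here, no measured step bears on this change. The estimated step that the limit leaves unreadable from compound 2 to compound 3 is expected to be moderate and to point toward lower toxicity in this assay. Compound 3 is expected at 6000 nM, with an estimated range of 1200 nM to 33000 nM.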

Compound 3, half-maximal cytotoxic concentration: > 33000 nM
Compound 3 was reported as a limit (the forecaster's own chance of this, stated with the estimate: 65%); middle value at least 5.5-fold (0.74 log units) away from the limit.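

Going by these compounds alone, compound 2 and compound 3 are both reported only as limits in this assay, so no step between them can be read. The compounds shown leave open whether replacing cyclohexyl with (cyclopent-1-en-1-yl)methyl changes toxicity in this assay at all.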